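The compounds below may be only part of what the source reports. "The series", "measured", "known", "first", "only" and "open" are said of these compounds alone.

Measured so far: compound 1 `CCOC(=O)c1c(-c2c(Cl)c3ccccc3oc2=O)nn(-c2ccc(OC)cc2)c1C(=O)OCC` gives 27000 nM in a functional assay on HeLa cells (Homo sapiens) for cytotoxicity, read by MTT assay, with a stated time of 48 h; on this read-out higher numbers stand for weaker inhibition and lower numbers for stronger inhibition. Compound 2 `CCOC(=O)c1c(-c2cc3ccccc3oc2=O)nn(-c2ccccc2)c1C(=O)OCC` gives 100000 nM. Compound 3 `CCOC(=O)c1c(-c2cc3ccccc3oc2=O)nn(-c2ccc(C)c(C)c2)c1C(=O)OCC` gives 50000 nM.

Compound 3 stands second highest of the three numbers; its nearest neighbour is compound 1 and its furthest compound 2, both gaps within the scatter, so no order among the three is claimed. Compound 4 `CCOC(=O)c1c(-c2cc3ccccc3oc2=O)nn(-c2ccc(OC)cc2)c1C(=O)OCC` is not yet measured. It differs from compound 3 in one place: 4-methoxyphenyl in place of 3,4-dimethylphenyl on an aromatic nitrogen. For the measured compounds named here, the only measured step at that position is a 2.0-fold lower number from compound 2 to compound 3 (0.30 log units; within the scatter), within the scatter. Going by the values given here, compound 1 also carries 4-methoxyphenyl but differs from compound 3 in more than one place, so no single step is drawn from it. Accordingly no change beyond the scatter is expected. Compound 4 is estimated at 35000 nM, range 12000 nM to 100000 nM. The expected step is a 1.4-fold lower number from compound 3 to compound 4 (0.15 log units; within the scatter).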

Compound 4, half-maximal inhibitory concentration: 90000 nM
For compound 4 the middle estimate is 2.6-fold (0.41 log units) below the measured one; the range from low to high includes it.
By their numbers in this assay, from the lowest: compounds 1, 3, 4 and 2 (each within the scatter of the next, the first and the last beyond it).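

In this assay the group on the aromatic nitrogen shows no separation among phenyl, 3,4-dimethylphenyl and 4-methoxyphenyl: methoxy in place of hydrogen gives a 1.1-fold lower number from compound 2 to compound 4 (0.05 log units; within the scatter) and 4-methoxyphenyl in place of 3,4-dimethylphenyl gives a 1.8-fold higher number from compound 3 to compound 4 (0.26 log units; within the scatter) on the shared core. For the compounds shown here, the one step beyond the scatter lies on the core instead, where hydrogen in place of chloro gives a 3.3-fold higher number from compound 1 to compound 4 (0.52 log units; beyond the scatter) with 4-methoxyphenyl held constant.

From the compounds shown here alone, whether an amine or a carboxylic acid on the nitrogen-bound phenyl would leave this flat range stays open, as does whether the chloro step holds with other groups on the nitrogen. Nothing on hand explains the chloro step.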